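Azoxy series: replacing the acetyl with ethyl on compound 1

The source may hold more compounds than are shown below. What is called first, only, known or untested is meant among the compounds shown, and "the series" means these compounds.

Working notes on a small azoxy set tested in a functional assay on HUVEC cells (Homo sapiens) for antiproliferative activity; a lower number here means a stronger inhibitor of growth, a higher number a weaker inhibitor of growth. Compound 1 `COC[C@H](/N=[N+](\[O-])CCCCCCC(C)=O)[C@H](C)O` carries an acetyl at the end of its chain. In this assay compound 1 gives > 50 ug/mL, which is a limit of the assay and not a number. Two relatives with unsaturated chains have been measured: compound 2 `CCCCCC(O)/C=C/[N+]([O-])=N/[C@@H](COC)[C@H](C)O` gives 31.2 ug/mL, and compound 3 `CCCCCC/C=C\[N+]([O-])=N\[C@@H](COC)[C@H](C)O` gives 30.4 ug/mL. The two sit close to each other, with compound 1 set apart only by the limit of > 50 ug/mL in this assay, at which 1 of the 3 values shown sits.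

Compound 4 `CCCCCCCC/[N+]([O-])=N/[C@@H](COC)[C@H](C)O` has not been measured. It differs from compound 1 by ethyl in place of acetyl on a saturated chain carbon, six bonds along the chain from a double-bonded nitrogen. For the measured compounds named here, no step between measured compounds maps this exchange, so the direction is open. The nearest comparison is that the chains without the acetyl, in compound 2 and compound 3, return numbers where compound 1 returns only a limit. On that basis the expected step of an at least 1.2-fold lower number from compound 1 to compound 4 (0.09 log units; that floor lies within the scatter) is toward a stronger inhibitor, but modest and with a real chance that the assay again reports only a limit. The estimate for compound 4 is 40 ug/mL, with a range from 18 ug/mL to 60 ug/mL.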

Compound 4, concentration for 50% growth inhibition: > 50 ug/mL
Compound 4: no number, only a limit; the forecaster's own chance of this, stated with the estimate: 40%; middle value at least 1.2-fold (0.09 log units) from the limit.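

In this assay compound 4, like compound 1, returns a limit of the assay and not a number, so no step can be read between compound 1 and compound 4: the limit of > 50 ug/mL in this assay, at which 2 of the 4 values shown sit. The compounds shown leave open whether ethyl in place of acetyl changes growth inhibition at all, in either direction.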